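From isopropoxy to butoxy on the shared core

The source may report more compounds than this note shows. Statements on the series, on what has been measured and on what is new or still open speak of the compounds shown alone.

Compound 1 `CCOC(=O)c1ccc(-c2ccc(N(CC)CC)nn2)cc1`: 1500 nM
Compound 2 `CCOC(=O)c1ccc(-c2ccc(OC(C)C)nn2)cc1`: > 25000 nM
Compound 3 `CCCCOc1ccc(-c2ccc(C(=O)OCC)cc2)nn1`: not yet measured

In a functional assay on NCI-H727 cells (Homo sapiens) for antiproliferative activity, with a stated time of 48 h (on this read-out lower numbers stand for stronger inhibition and higher numbers for weaker inhibition), compound 2 gives > 25000 nM, which is a limit and not a number.

Compound 3 carries butyl in place of isopropyl on an oxygen on an aromatic ring. For the measured compounds named here, the only measured step is large: an at least 16-fold higher number from compound 1 to compound 2 (1.22 log units; beyond the scatter), with isopropoxy in place of diethylamino on an aromatic carbon. Compound 3 keeps the oxygen that arrived with that step, so no change beyond the scatter is expected in this assay. The expected step is an at least 1.2-fold lower number from compound 2 to compound 3 (0.09 log units; that floor lies within the scatter). For compound 3 the estimate is 20000 nM, with an expected range of 6000 nM to 40000 nM.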

Compound 3, half-maximal inhibitory concentration: > 25000 nM
Compound 3: a limit, no number (the forecaster's own chance of this, stated with the estimate: 55%); middle value at least 1.2-fold (0.09 log units) from the limit.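

Replacing diethylamino with butoxy on an aromatic carbon gives an at least 16-fold higher number from compound 1 to compound 3 (1.22 log units; beyond the scatter) in this assay. The large loss seen with isopropoxy therefore also appears with a second, different chain on the oxygen. Compound 3 ends at a limit and not a number, as compound 2 does, so the change from isopropoxy to butoxy cannot be read: the limit of > 25000 nM in this assay, at which 2 of the 3 values shown sit.

From the compounds shown here alone, whether a hydroxyl-bearing chain on this oxygen would give a measurable number remains open. So does how a smaller amine, such as dimethylamino, or a ring amine, such as morpholine, compares with the diethylamino group of compound 1.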